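The compounds below may be only part of what the source reports. "The series", "measured", "known", "first", "only" and "open" are said of these compounds alone.

In a functional assay on A-375 cells (Homo sapiens) for inhibition, read by CCK-8 assay, with a stated time of 72 h, tested at 8 uM (a higher number here means more inhibition of growth at the concentration tested, a lower number less inhibition of growth), compound 1 (`COc1ccc(SCc2ccc(C(=O)Nc3ccccc3N)cc2)cc1`) gives 81.8%. Compound 3 (`COc1ccc(SCc2ccc(C(=O)Nc3ccccc3N)cc2)cc1OC`) gives 84.6%, and the two stand level within the scatter. Compound 2 (`Nc1ccccc1NC(=O)/C=C/c1ccc(CSCCc2ccccc2)cc1`) gives 37.4%, a value far lower than the other two, so compound 1 belongs to the upper pair of these three numbers.

The next compound is compound 4 (`Cc1cc(C)cc(SCc2ccc(C(=O)Nc3ccccc3N)cc2)c1`), which keeps the core of compound 1 and exchanges one group: 3,5-dimethylphenyl in place of 4-methoxyphenyl on a sulfur, (3,5-dimethylphenyl in place of 4-methoxyphenyl on a sulfur). Within the data shown here, only one measured step touches the same group. This is a number 2.8 percentage points higher from compound 1 to compound 3 (within the scatter), where a methoxy takes the place of hydrogen on an aromatic carbon, and it stays within the scatter. Among the measured compounds shown here, that step offers modest guidance, since no measured compound lacks the methoxy or carries a methyl on this ring. The data therefore give no ground for predicting a real shift in either direction, though they cannot exclude a loss. For the measured compounds named here, the expected change is a number 2.8 percentage points lower from compound 1 to compound 4 (within the scatter), an estimate that lies within the scatter and so amounts to no real step. Compound 4 is expected to give 79%, with an estimated range from 60% to 92%.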

Compound 4, percent growth inhibition at one concentration: 74.7%
Estimate against measurement, compound 4: 4.3 percentage points above; low and high end bracket the measured number.
By their numbers in this assay, from the lowest: compound 2; then compounds 4, 1 and 3 (each within the scatter of the next).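

In this assay, replacing 4-methoxyphenyl with 3,5-dimethylphenyl on the sulfur gives a number 7.1 percentage points lower from compound 1 to compound 4 (within the scatter), so compound 4 stands level with compound 1. The earlier step from compound 1 to compound 3 only added a methoxy to a ring that already carried one, whereas this exchange leaves no oxygen on the ring at all: the entering group has 0 hydrogen-bond acceptors against 1 for the group that leaves, and the heavy-atom count stays at 8. In this pair, then, the methoxy oxygen is not needed to keep the inhibition of growth at the level of compound 1, although nothing available here explains why the exchange is accepted.

The step removes the methoxy and adds the two methyl groups at once, so the compounds shown cannot separate the two parts of the exchange, and they do not show how an unsubstituted phenyl, a chlorophenyl or an aminophenyl on the sulfur would behave. Going by these compounds, whether a carboxylic acid on this ring or a longer chain between the sulfur and the ring would hold the same level also stays open.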